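Trifluoromethyl on the Aromatic Ring of Compound 1

The compounds below may be only part of what the source reports. "The series", "measured", "known", "first", "only" and "open" are said of these compounds alone.

Measured so far:
compound 1 `C1=NCC(CC2=Cc3ccccc3CC2)N1`: 50.1 nM
compound 2 `Clc1cccc2c1C=C(CC1CN=CN1)CC2`: 50.1 nM
compound 3 `Cc1cccc2c1C=C(CC1CN=CN1)CC2`: 1000 nM

In a functional assay for binding affinity to Norepinephrine transporter (Rattus norvegicus), read by radioligand binding, in the presence of a further agent that is not named here (a higher number here means a weaker inhibitor, a lower number a stronger inhibitor), compound 1 gives 50.1 nM, level with compound 2 within the scatter, and these two share the lowest number of the three; the step of a 20-fold higher number from compound 1 to compound 3 (1.30 log units; beyond the scatter) sets compound 3 apart. Compound 4 `FC(F)(F)c1ccc2c(c1)C=C(CC1CN=CN1)CC2` differs from compound 1 by trifluoromethyl in place of hydrogen on an aromatic carbon. Within the data shown here, two measured steps concern a group entering the same aromatic ring: no change at the digits printed from compound 1 to compound 2 (within the scatter) and a 20-fold higher number from compound 1 to compound 3 (1.30 log units; beyond the scatter). Neither involves trifluoromethyl, and they point in different directions, so a substituent here may leave the number unchanged or raise it strongly. A moderate rise is therefore expected, a 3.0-fold higher number from compound 1 to compound 4 (0.48 log units; beyond the scatter), with wide uncertainty. Compound 4 is estimated at 150 nM, between 35 nM and 800 nM.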

Compound 4, inhibition constant: < 10000 nM
Compound 4: no number, only a limit; the forecaster's own chance of this, stated with the estimate: 5%; the middle value is on the limit's open side.
By their numbers in this assay, from the lowest: compounds 1 and 2 (each within the scatter of the next); then compound 3.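

Compound 4 gives only a limit and not a number, so the step from compound 1 to compound 4 cannot be read: the limit of < 10000 nM in this assay, at which 1 of the 4 values shown sits. As far as these compounds go, whether trifluoromethyl on this aromatic ring changes the number of compound 1, and by how much, stays open.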